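Cytotoxicity limits across three analogues and a methyl replacement

This account rests on a few compounds, and the source may have more. Where it says the series, first, only, none or still open, it means among the compounds named here.

Measured compounds:
Compound 1 `Fc1cccc(F)c1Cn1cccc2nc(-c3c(F)cccc3F)nc1-2`: > 100000 nM
Compound 2 `Cc1ccn(Cc2c(F)cccc2F)c2nc(-c3c(F)cccc3F)nc1-2`: > 100000 nM
Compound 3 `COc1cccc(Cn2ccc3nc(-c4ccccc4)nc-3c2)c1`: > 100000 nM

In an ADME assay on MDBK cells (Bos taurus) for cytotoxicity (on this read-out lower numbers stand for higher toxicity in this test and higher numbers for lower toxicity in this test), compound 1 reaches only a limit, > 100000 nM. In this assay compound 2 likewise reaches only a limit, > 100000 nM. In this assay compound 3 also gives only a limit, > 100000 nM. So compound 3 stands where every value shown stands: the limit of > 100000 nM in this assay, at which 3 of the 3 values shown sit.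

Compound 4 `CCn1ccc2nc(-c3ccccc3)nc-2c1` differs from compound 3 in one place: methyl in place of 3-methoxyphenyl on a saturated chain carbon bound to an aromatic nitrogen.

Only one measured step exists among these compounds, and it is a step that the two limits leave unreadable from compound 1 to compound 2; both of its ends are limits, so its size cannot be read, and it concerns a different change from the one between compound 3 and compound 4. Among the compounds with values here, no measured step bears directly on replacing the 3-methoxyphenyl by a methyl. All three values shown are limits, so nothing among them indicates a compound in this series reaching measurable toxicity in this assay.

On that basis compound 4 is expected to show a step that the limit leaves unreadable from compound 3 to compound 4, that is, none beyond the scatter, in this assay. The estimate for compound 4 in this assay is 150000 nM, ranging from 60000 nM to 400000 nM, most likely reported again as a limit.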

Compound 4, half-maximal cytotoxic concentration: > 100000 nM
Compound 4: only a limit was reported (the forecaster's own chance of this, stated with the estimate: 80%); the middle value lies beyond the limit too.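

In this assay compound 4 gives > 100000 nM, which is a limit and not a number. Within the data shown here, compound 3 and compound 4 both rest on limits, so no step between them can be read. The compounds shown leave open at what concentration, if any, compounds 1 to 4 would show toxicity in this assay.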